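The source may report more compounds than this note shows. Statements on the series, on what has been measured and on what is new or still open speak of the compounds shown alone.

In a physicochemical assay for acid dissociation, compound 1 `COc1cccc(Oc2ccc3c(NCCCNCc4ccco4)ccnc3c2)c1` gives 9.28 while compound 2 `Fc1ccc(Cc2ccc3c(NCCCNCc4ccco4)ccnc3c2)cc1` gives 9.47 and compound 3 `CCC(CC)c1ccc2c(NCCCNCc3ccco3)ccnc2c1` gives 9.47 so compound 2 stands level with compound 3 at the digits shown, and compound 1 lies within the scatter of both. The change to compound 4 `FC(F)(F)c1cccc(Cc2ccc3c(NCCCNCc4ccco4)ccnc3c2)c1` is 3-(trifluoromethyl)phenyl in place of 4-fluorophenyl on a saturated chain carbon bound to an aromatic carbon and it falls on a saturated chain carbon bound to an aromatic carbon. Among the measured compounds shown here, no measured step makes this exact exchange, so the evidence is indirect. Replacing the whole group on the aromatic carbon gives a number 0.19 log units higher from compound 1 to compound 2 (within the scatter) and also no change at the digits printed from compound 2 to compound 3 (within the scatter) and neither goes beyond the scatter. On those two steps, the exchange in compound 4 is likewise expected to stay within the scatter in this assay with neither a higher nor a lower number more likely than the other. The expected step is a number 0.05 log units lower from compound 2 to compound 4 (within the scatter) and it is not expected to be distinguishable from no change. For compound 4 the estimate is 9.42 with an expected range from 9.1 to 9.7 for now.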

Compound 4, acid dissociation constant: 9.47
For compound 4 the middle estimate is 0.05 log units below the measured one, and the stated range covers the measured number.
By their numbers in this assay, from the lowest: compounds 1, 2, 3 and 4 (each within the scatter of the next).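

Putting 3-(trifluoromethyl)phenyl in place of 4-fluorophenyl on a saturated chain carbon bound to an aromatic carbon gives, in this assay, no change at the digits printed from compound 2 to compound 4 (within the scatter). Among the compounds shown here, the earlier steps replaced the whole group on the aromatic carbon, so this is the first direct reading of an exchange at the saturated chain carbon, with the whole group on the aromatic carbon otherwise kept in place. The exchange takes the group from 7 to 10 heavy atoms and adds no hydrogen-bond donor, acceptor or net charge, and nothing available bears on why the number holds.

The compounds shown leave open whether an amine or a carboxylic acid in place of the aromatic ring on that saturated chain carbon would also stay within the scatter in this assay. Every exchange here brings in an uncharged group without donors or acceptors on this carbon, so such groups remain an untested case.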